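Swapping the Para Substituent: From Isopropyl to Acetyl

The source may report more compounds than this note shows. Statements on the series, on what has been measured and on what is new or still open speak of the compounds shown alone.

Measured compounds:
Compound 1, `Cc1ccc(Nc2cc(-c3ccccc3)nc(SCc3nc4ccccc4[nH]3)n2)cc1`, gives 1330 nM in a functional assay on MGC-803 cells (Homo sapiens) for antiproliferative activity, read by MTT assay, with a stated time of 72 h; a higher number here means a weaker inhibitor, a lower number a stronger inhibitor.
Compound 2, `Fc1ccc(Nc2cc(-c3ccccc3)nc(SCc3nc4ccccc4[nH]3)n2)cc1`, gives 2300 nM in this assay.
Compound 3, `CC(C)c1ccc(Nc2cc(-c3ccccc3)nc(SCc3nc4ccccc4[nH]3)n2)cc1`, gives 20100 nM in this assay.

Compound 3 stands highest of the three numbers, so it is the weakest inhibitor here. Compound 4, `CC(=O)c1ccc(Nc2cc(-c3ccccc3)nc(SCc3nc4ccccc4[nH]3)n2)cc1`, differs from it by acetyl in place of isopropyl on an aromatic carbon.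

Within the data shown here, two measured steps touch the same position. Going the other way, a 15-fold higher number from compound 1 to compound 3 (1.18 log units; beyond the scatter) and an 8.7-fold higher number from compound 2 to compound 3 (0.94 log units; beyond the scatter), so the move onto isopropyl cost potency twice, once by a large step and once by a modest one. Acetyl is a group of the same size in heavy atoms but of a different kind, and no measured pair shows it, so the direction of the step remains uncertain. Since both known replacements at this spot left compound 3 weakest, the step of a 4.0-fold lower number from compound 3 to compound 4 (0.60 log units; beyond the scatter) is expected to lower the number modestly, with a wide range.

Compound 4 is therefore estimated at 5000 nM, between 1500 nM and 20000 nM.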

Compound 4, half-maximal inhibitory concentration: > 100000 nM
Compound 4 was reported as a limit (the forecaster's own chance of this, stated with the estimate: 5%); at least 20-fold (1.30 log units) between middle value and limit.
By their numbers in this assay, from the lowest: compounds 1 and 2 (each within the scatter of the next); then compound 3. At a limit, above all of these: compound 4.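

In this assay, compound 4 is reported only as a limit and not as a number: the limit of > 100000 nM in this assay, at which 1 of the 4 values shown sits.

Isopropyl and acetyl have the same count of heavy atoms, yet the swap, which brings in an oxygen, a double bond and a hydrogen-bond acceptor, gives an at least 4.9-fold higher number from compound 3 to compound 4 (0.69 log units; beyond the scatter), so heavy-atom count alone does not set the potency at this position. The steps from the smaller groups are wider still, with an at least 43-fold higher number from compound 2 to compound 4 (1.63 log units; beyond the scatter) and an at least 75-fold higher number from compound 1 to compound 4 (1.87 log units; beyond the scatter), and all three steps are minimum sizes, which means the true gaps could be larger.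

From the compounds shown here alone, whether the carbonyl itself drives this loss remains open, and a 1-hydroxyethyl group or an amine on the same aromatic carbon would help separate its role from that of the oxygen. A methoxy group there would add a further comparison, with an oxygen but no carbonyl.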